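Ethoxy for methyl on a second core

A few compounds are considered here, and "the series" means these few. Any claim that something is new, unique, unknown or untested is made for them only; others in the source may bear on it.

Of the compounds shown here, three have been measured in a functional assay on K562 cells (Homo sapiens) for antiproliferative activity, read by MTT assay, with a stated time of 72 h; on this read-out higher numbers stand for weaker inhibition and lower numbers for stronger inhibition. Compound 1 `COc1cc(C(=O)c2sc3ccccc3c2-c2ccc(C)cc2)cc(OC)c1OC` gives 3500 nM, and compound 2 `CCOc1ccc(-c2c(C(=O)c3cc(OC)c(OC)c(OC)c3)sc3ccccc23)cc1` gives 3100 nM. These two differ in one place: ethoxy in place of methyl on an aromatic carbon. The step they make is a 1.1-fold lower number from compound 1 to compound 2 (0.05 log units; within the scatter), so on this core the change leaves the number essentially where it was.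

Compound 3 `COc1cc(C(=O)c2sc3cc(C)ccc3c2Nc2ccc(C)cc2)cc(OC)c1OC` belongs to a different core; how it differs from compound 1 is not broken down here. In this assay compound 3 gives 1400 nM, which is the lowest of the three numbers and stands beyond the scatter from both compound 2 and compound 1.

Compound 4 `CCOc1ccc(Nc2c(C(=O)c3cc(OC)c(OC)c(OC)c3)sc3cc(C)ccc23)cc1` has not yet been measured. It is related to compound 3 as compound 2 is to compound 1: ethoxy in place of methyl on an aromatic carbon. The place lines of the two changes read the same word for word, so this is the same change made on a second core.

Going by the values given here, the only guide to its effect is the pair already measured. Because that pair moved by a 1.1-fold lower number from compound 1 to compound 2 (0.05 log units; within the scatter), compound 4 is expected to sit close to compound 3, with an expected step of a 1.1-fold lower number from compound 3 to compound 4 (0.03 log units; within the scatter). The estimate rests on a single earlier example, so the range around it is kept wide. For compound 4 the expected value is 1300 nM, with a likely span from 550 nM to 3000 nM.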

Compound 4, half-maximal inhibitory concentration: 4300 nM
The estimate for compound 4 lay 3.3-fold (0.52 log units) below the measured number; measured number outside the range, above it.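

On the core of compound 3, ethoxy in place of methyl does not leave the number where it was: in this assay the change gives a 3.1-fold higher number from compound 3 to compound 4 (0.49 log units; beyond the scatter), and a higher number here stands for weaker inhibition. Set beside the earlier pair, the same change at the same kind of place has not behaved alike on the two cores: the same change on two cores in this assay, a 1.1-fold lower number (0.05 log units; within the scatter) from compound 1 to compound 2 and a 3.1-fold higher number (0.49 log units; beyond the scatter) from compound 3 to compound 4, 3.5-fold (0.54 log units) apart, beyond the scatter of two such steps. This shows that, in these two pairs, the result of the change cannot simply be carried from one core to the other, but it does not show which part of the cores makes the difference, and two pairs are too few to support a rule for the wider series.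

The compounds shown leave open how other groups would behave at this place on the core of compound 3, such as a hydroxyl, an amine or a longer chain like propoxy, and so whether the weaker inhibition seen with ethoxy would grow, shrink or vanish as the group changes. They also leave open whether a third core would follow the pattern of compound 1 and compound 2 or that of compound 3 and compound 4.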